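Swapping an Aromatic Ester for a Pivalate in a Cytotoxicity Series

The source may hold more compounds than are shown below. What is called first, only, known or untested is meant among the compounds shown, and "the series" means these compounds.

Compound 1 `C=C1[C@H](OC(C)=O)[C@@H](OC(=O)C(C)(C)C)[C@@H](OC(C)=O)C(C)(C)/C=C/[C@H](C)[C@H](OC(=O)c2ccccc2)[C@@]2(O)C[C@@](C)(OC(C)=O)[C@H](OC(C)=O)[C@@H]2[C@H]1OCC(C)C` and compound 2 `C=C1[C@H](OC(C)=O)[C@@H](OC(=O)c2cccc(C)c2)[C@@H](OC(C)=O)C(C)(C)/C=C/[C@H](C)[C@H](OC(=O)c2ccccc2)[C@@]2(O)C[C@@](C)(OC(C)=O)[C@H](OC(C)=O)[C@@H]2[C@H]1OCC(C)C` share one core and differ only in one ester group: tert-butyl in place of 3-methylphenyl on a carbonyl carbon. In a toxicity assay on HEK-293T cells (Homo sapiens) for cytotoxicity, read by MTT assay, with a stated time of 48 h (on this read-out higher numbers stand for weaker inhibition and lower numbers for stronger inhibition), compound 2 gives 7600 nM. In this assay compound 1 gives 18900 nM. That change made a 2.5-fold higher number from compound 2 to compound 1 (0.40 log units; beyond the scatter). Compound 3 `C=C1[C@H](OC(C)=O)[C@@H](OC(=O)c2cccc(C)c2)[C@@H](OC(C)=O)C(C)(C)/C=C/[C@H](C)[C@H]2O[C@]3(C)C[C@@]2(OC(=O)c2ccccc2)[C@H]([C@H]3OC(C)=O)[C@H]1OCC(C)C` carries a different core, and the difference between the two cores is not broken down here. In this assay compound 3 reports only a limit, > 100000 nM, (the limit of > 100000 nM in this assay, at which 1 of the 3 values shown sits). Compound 4 `C=C1[C@H](OC(C)=O)[C@@H](OC(=O)C(C)(C)C)[C@@H](OC(C)=O)C(C)(C)/C=C/[C@H](C)[C@H]2O[C@]3(C)C[C@@]2(OC(=O)c2ccccc2)[C@H]([C@H]3OC(C)=O)[C@H]1OCC(C)C` repeats the same kind of change on the core of compound 3: tert-butyl in place of 3-methylphenyl on a carbonyl carbon. Because compound 3 already sits at the limit > 100000 nM, compound 4 is expected to remain at or beyond it, with an estimated step that the limit leaves unreadable from compound 3 to compound 4. The estimate for compound 4 is 200000 nM, between 80000 nM and 600000 nM.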

Compound 4, half-maximal inhibitory concentration: > 100000 nM
Compound 4: no number, only a limit; the forecaster's own chance of this, stated with the estimate: 85%; the middle value does not contradict the limit.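

In this assay, among the compounds shown here, compound 4 gives only a limit, > 100000 nM, as compound 3 also does, so no step between compound 3 and compound 4 can be read. From the compounds shown here alone, whether tert-butyl in place of 3-methylphenyl changes cytotoxicity on the core of compound 3 stays open.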